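Methoxyphenyl isomers on the shared core: working notes

A few compounds are considered here, and "the series" means these few. Any claim that something is new, unique, unknown or untested is made for them only; others in the source may bear on it.

Values in an ADME assay on Huh-7 cells (Homo sapiens) for cytotoxicity, read by MTT assay, with a stated time of 72 h; a higher number here means that more compound is tolerated, a lower number that less compound is tolerated:
compound 1, `NC(=O)c1sc2nc(-c3ccccc3)cc(C(F)(F)F)c2c1N`: > 20000 nM (a limit of the assay)
compound 2, `COc1ccc(-c2cc(C(F)(F)F)c3c(N)c(C(N)=O)sc3n2)cc1`: 46400 nM
compound 3, `COc1cccc(-c2cc(C(F)(F)F)c3c(N)c(C(N)=O)sc3n2)c1`: > 20000 nM (a limit of the assay)

Compound 3 stands only at a limit in this assay, with no number of its own. Compound 3 sits at the limit of > 20000 nM in this assay, at which 2 of the 3 values shown sit. Going by the values given here, compound 2 is the one member of the set with a number in this assay, 46400 nM.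

Compound 4, `COc1ccccc1-c1cc(C(F)(F)F)c2c(N)c(C(N)=O)sc2n1`, has not been measured in this assay. The change from compound 3 is 2-methoxyphenyl in place of 3-methoxyphenyl on an aromatic carbon. Among the compounds with values here, the steps that bear on it are all unreadable: a step that the limit leaves unreadable from compound 2 to compound 3, the only step that moves the methoxy around the phenyl, as well as a step that the limit leaves unreadable from compound 1 to compound 2 and a step that the two limits leave unreadable from compound 1 to compound 3. No readable step exists in this assay among the three measured compounds, so no step beyond the scatter is expected in this assay from compound 3 to compound 4, and a further limit is the most likely outcome.

Compound 4 is therefore expected to give 40000 nM in this assay, within 20000 nM to 100000 nM, and the step that the limit leaves unreadable from compound 3 to compound 4 is an estimate carrying the width of an unreadable reference.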

Compound 4, half-maximal cytotoxic concentration: > 20000 nM
Compound 4: a limit, no number; the forecaster's own chance of this, stated with the estimate: 60%; the middle value is on the limit's open side.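

In this assay compound 4 gives > 20000 nM as a limit and not a number. No new step can be read from it to compound 1, compound 2 or compound 3. The compounds shown leave open whether moving the methoxy around the phenyl changes tolerance at all, since most values share one limit: the limit of > 20000 nM in this assay, at which 3 of the 4 values shown sit.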